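A Dichlorophenyl Replacement at the Sulfonyl Sulfur

This account rests on a few compounds, and the source may have more. Where it says the series, first, only, none or still open, it means among the compounds named here.

Three compounds share one core and differ only in the group on the sulfonyl sulfur: compound 1 `Cc1noc(C)c1S(=O)(=O)N1CCC(N2CCC(C)CC2)CC1` carries a 3,5-dimethyl-1,2-oxazol-4-yl, compound 2 `CC1CCN(C2CCN(S(=O)(=O)c3cccnc3F)CC2)CC1` a 2-fluoropyridin-3-yl, and compound 3 `COc1cccc(S(=O)(=O)N2CCC(N3CCC(C)CC3)CC2)c1` a 3-methoxyphenyl. In a functional assay on DLD-1 cells (Homo sapiens) for antiproliferative activity, read by CellTiter-Glo, with a stated time of 72 h (on this read-out higher numbers stand for weaker inhibition and lower numbers for stronger inhibition), compound 1 returns only a limit, > 5000 nM. In this assay compound 2 likewise returns only a limit, > 5000 nM. Compound 3 stands in the same place, with only a limit of > 5000 nM in this assay. All three therefore sit at the limit of > 5000 nM in this assay, at which 3 of the 3 values shown sit, and the steps a step that the two limits leave unreadable from compound 1 to compound 2, a step that the two limits leave unreadable from compound 1 to compound 3 and a step that the two limits leave unreadable from compound 2 to compound 3 cannot be sized. Compound 4 `CC1CCN(C2CCN(S(=O)(=O)c3ccc(Cl)c(Cl)c3)CC2)CC1` differs from compound 3 by 3,4-dichlorophenyl in place of 3-methoxyphenyl on a sulfonyl sulfur. Among the compounds with values here, no measured step bears readably on this change, so no step beyond the scatter can be foreseen. The step this estimate implies, a step that the limit leaves unreadable from compound 3 to compound 4, is expected to be small. Compound 4 is therefore expected to give about 8000 nM in this assay, between 2000 nM and 30000 nM, most likely again as a limit.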

Compound 4, half-maximal inhibitory concentration: 2.9 nM
Compound 4: middle estimate off by 2800-fold (3.44 log units), on the high side; measured number outside the range, below it.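

Compound 4 shows that the group on the sulfonyl sulfur can decide the outcome in this assay: 3,4-dichlorophenyl in place of 3-methoxyphenyl gives a large step (an at least 1700-fold lower number from compound 3 to compound 4 (3.23 log units; beyond the scatter)). The same entering group gives matching steps against the other two groups, 2-fluoropyridin-3-yl (an at least 1700-fold lower number from compound 2 to compound 4 (3.23 log units; beyond the scatter)) and 3,5-dimethyl-1,2-oxazol-4-yl (an at least 1700-fold lower number from compound 1 to compound 4 (3.23 log units; beyond the scatter)). Of the four groups shown at this place, only 3,4-dichlorophenyl yields a number and not a limit: the limit of > 5000 nM in this assay, at which 3 of the 4 values shown sit.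

As far as these compounds go, what 3-chlorophenyl or 4-chlorophenyl would give on the shared core stays open, so the step cannot be assigned to one chlorine or to the pair. From the compounds shown here alone, whether 3,4-difluorophenyl or 3,4-dimethylphenyl would keep such a low number is equally open.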